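Two benzamide thiocarbamates and an untested fluorophenyl analogue

The source may report more compounds than this note shows. Statements on the series, on what has been measured and on what is new or still open speak of the compounds shown alone.

Measured compounds:
compound 1 `Nc1ccccc1NC(=O)c1ccc(CSC(=S)N2CCN(c3cccnc3)CC2)cc1`: 40.5%
compound 2 `CCN(Cc1ccncc1)C(=S)SCc1ccc(C(=O)Nc2ccccc2N)cc1`: 67.2%

The account concerns two compounds measured in a functional assay on A-375 cells (Homo sapiens) for antiproliferative activity, read by CCK-8 assay, with a stated time of 72 h, tested at 2 uM (on this read-out higher numbers stand for a stronger effect at the one concentration tested and lower numbers for a weaker effect), and one that has not been tested. Compound 1 `Nc1ccccc1NC(=O)c1ccc(CSC(=S)N2CCN(c3cccnc3)CC2)cc1` gives 40.5% in this assay, the lower of the two numbers. Compound 2 `CCN(Cc1ccncc1)C(=S)SCc1ccc(C(=O)Nc2ccccc2N)cc1` gives 67.2% in this assay, a difference from compound 1 that is beyond the scatter. The two compounds differ in more than one place, so no single change can be assigned to that gap.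

Compound 3 `Nc1ccccc1NC(=O)c1ccc(CSC(=S)N2CCN(c3ccccc3F)CC2)cc1` differs from compound 1 in one place: 2-fluorophenyl in place of pyridin-3-yl on an amine nitrogen in a ring. Among the compounds with values here, there is no measured pair to show what this exchange does in this assay. A small step is expected, in either direction, not beyond the scatter, and the estimated step of a number 5.5 percentage points higher from compound 1 to compound 3 (within the scatter) reflects that. Compound 3 is therefore expected to give about 46% in this assay, with a range from 28% to 66%.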

Compound 3, a percentage reported as inhibition, at one concentration (the size of the read-out at that concentration, not a potency): 18.7%
Compound 3: middle estimate off by 27.3 percentage points, on the high side; the whole stated range lies above it.
By their numbers in this assay, from the lowest: compound 3; then compound 1; then compound 2.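

Within the data shown here, the exchange of pyridin-3-yl for 2-fluorophenyl on the amine nitrogen of the six-membered ring gives the first one-place comparison in this set: in this assay it is a number 21.8 percentage points lower from compound 1 to compound 3 (beyond the scatter). This position is therefore not indifferent in this assay, since one exchange there moves the read-out beyond the scatter. The exchange removes a ring nitrogen with its hydrogen-bond acceptor and brings in a fluorine, and nothing available gives a reason for the step.

The compounds shown leave open whether the step follows from losing the ring nitrogen or from gaining the fluorine, a question that a plain phenyl group on the same nitrogen would help to separate. They also leave open whether pyridin-2-yl or pyridin-4-yl at this position would behave like pyridin-3-yl.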